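From 4-nitrobenzyl to 2-cyanobenzyl: what size of step?

A few compounds are considered here, and "the series" means these few. Any claim that something is new, unique, unknown or untested is made for them only; others in the source may bear on it.

- Compound 1 `CCOC(=O)c1c(C)nc(-c2cccc(C#N)c2)n1OCc1ccccc1` gives 5930 nM
- Compound 2 `CCOC(=O)c1c(C)nc(-c2cccc(C#N)c2)n1OCc1ccc([N+](=O)[O-])cc1` gives 8750 nM

Both numbers come from a functional assay on a cell-free system (plasma, Oryctolagus cuniculus) for inhibition, with stated times of 5 min, 1 min and 6 min (on this read-out higher numbers stand for weaker inhibition and lower numbers for stronger inhibition), and they cannot be told apart, so compound 2 stands level with compound 1 on the numbers shown. The next molecule is compound 3 `CCOC(=O)c1c(C)nc(-c2cccc(C#N)c2)n1OCc1ccccc1C#N` and it differs from compound 2 by 2-cyanophenyl in place of 4-nitrophenyl on a saturated chain carbon bound to an oxygen on an aromatic ring which places 2-cyanophenyl in place of 4-nitrophenyl on a saturated chain carbon bound to an oxygen on an aromatic ring.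

Within the data shown here, only one measured step bears on this change. It is a 1.5-fold higher number from compound 1 to compound 2 (0.17 log units; within the scatter) and it comes from putting nitro in place of hydrogen on an aromatic carbon. Among the measured compounds shown here, that step is a thin guide, since no measurement yet shows what 2-cyanophenyl does here. No step beyond the scatter is therefore expected in this assay and neither direction is favoured with any confidence. The expected step is a 1.3-fold lower number from compound 2 to compound 3 (0.10 log units; within the scatter) and it remains an estimate until measured. For compound 3 the estimated value is 7000 nM with an expected range from 2800 nM to 17000 nM as a deliberately wide span.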

Compound 3, half-maximal inhibitory concentration: 9380 nM
The estimate for compound 3 lay 1.3-fold (0.13 log units) below the measured number; the measured number falls inside the stated range.
By their numbers in this assay, from the lowest: compounds 1, 2 and 3 (each within the scatter of the next).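

Replacing 4-nitrophenyl with 2-cyanophenyl gives a 1.1-fold higher number from compound 2 to compound 3 (0.03 log units; within the scatter) in this assay, so this exchange of one substituted aromatic ring for another, on a saturated chain carbon bound to an oxygen on an aromatic ring, does not give a step that can be told from ordinary repeat variation. The cyano group now has its own comparison with the unsubstituted ring, a 1.6-fold higher number from compound 1 to compound 3 (0.20 log units; within the scatter), and this step also lies within the scatter, as does the earlier one for nitro, so all three compounds shown cannot be told apart in this assay. No independent measurement is available to explain this result.

The compounds shown leave open whether a carboxylic acid or an amine on this aromatic ring, or a longer chain in place of the ring, would give a step beyond the scatter. They also leave open whether any change elsewhere on the shared core would move the number more than these changes do, since all three compounds carry the same core.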